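Changing the Aryl Group on the Aromatic Nitrogen

A few compounds are considered here, and "the series" means these few. Any claim that something is new, unique, unknown or untested is made for them only; others in the source may bear on it.

Compound 1, `CC1(C)[C@H]2CC[C@]1(C)N(Cc1cn(-c3ccc(F)cc3)nn1)C(=O)C2`: 40 nM
Compound 2, `CC1(C)[C@H]2CC[C@]1(C)N(Cc1cn(-c3ccccc3Cl)nn1)C(=O)C2`: 190 nM

For the measured compounds named here, in a functional assay on LoVo cells (Homo sapiens) for inhibition, read by MTT assay, with a stated time of 24 h (on this read-out higher numbers stand for weaker inhibition and lower numbers for stronger inhibition), compound 2 gives 190 nM, the higher of the two numbers measured so far. Going by the values given here, the one measured step, a 4.8-fold higher number from compound 1 to compound 2 (0.68 log units; beyond the scatter), shows that exchanging the aryl group on the aromatic nitrogen can shift the read-out well beyond the scatter. Compound 3 `COc1cccc(-n2cc(CN3C(=O)C[C@@H]4CC[C@@]3(C)C4(C)C)nn2)c1` differs from compound 2 by 3-methoxyphenyl in place of 2-chlorophenyl on an aromatic nitrogen. Among the compounds with values here, no measured pair contains 3-methoxyphenyl, so the direction of this change is open; a step of roughly the size already seen, in either direction, is plausible. Compound 3 is therefore expected to give about 100 nM, between 30 nM and 350 nM, an expected step of a 1.9-fold lower number from compound 2 to compound 3 (0.28 log units; within the scatter).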

Compound 3, half-maximal inhibitory concentration: 80 nM
Compound 3: the middle estimate sits 1.3-fold (0.10 log units) above what was measured; the measured number falls inside the stated range.
By their numbers in this assay, from the lowest: compounds 1 and 3 (each within the scatter of the next); then compound 2.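

Compound 3 shows that the aromatic nitrogen can carry a quite different aryl group and still give a low number: in this assay, 3-methoxyphenyl in place of 2-chlorophenyl gives a 2.4-fold lower number from compound 2 to compound 3 (0.38 log units; beyond the scatter). Compared with 4-fluorophenyl, the same group gives a 2.0-fold higher number from compound 1 to compound 3 (0.30 log units; within the scatter), so these two aryl groups cannot be told apart on this read-out. Nothing available explains these differences.

Each aryl ring carries a different group at a different place, so the effects of group and place remain tangled. Going by these compounds, how an unsubstituted phenyl or an aminophenyl would behave also stays open.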